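From 4-iodophenyl to 3-bromophenyl on the shared core

The compounds below may be only part of what the source reports. "The series", "measured", "known", "first", "only" and "open" are said of these compounds alone.

In a functional assay (muscle tissue) with Cavia porcellus as the target (a lower number here means that less compound is needed, a higher number that more compound is needed for the effect), compound 1 `COC(=O)C1=C(C)N=C(C)/C(=C(\O)OC)C1c1ccccc1N` gives 39800 nM, compound 2 `COC(=O)C1=C(C)N=C(C)/C(=C(\O)OC)C1c1cccc(O)c1` gives 1000 nM and compound 3 `COC(=O)C1=C(C)N=C(C)/C(=C(\O)OC)C1c1ccc(I)cc1` gives 22900 nM. Compound 3 sits with compound 1 at the high end of these three numbers: a 1.7-fold lower number from compound 1 to compound 3 (0.24 log units; within the scatter) stays within the scatter, whereas a 23-fold higher number from compound 2 to compound 3 (1.36 log units; beyond the scatter) is large.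

Compound 4 `COC(=O)C1=C(C)N=C(C)/C(=C(\O)OC)C1c1cccc(Br)c1` is the next case, with 3-bromophenyl in place of 4-iodophenyl on the saturated ring carbon: 3-bromophenyl in place of 4-iodophenyl on a saturated ring carbon. Going by the values given here, no measured compound carries bromine. Among the compounds with values here, the nearest guide is compound 2, the only measured compound with a 3-substituted phenyl group, and its two steps, a 40-fold lower number from compound 1 to compound 2 (1.60 log units; beyond the scatter) and a 23-fold higher number from compound 2 to compound 3 (1.36 log units; beyond the scatter), are both large. This is support from a single compound, so a large step to a lower number is expected in this assay, with wide uncertainty.

The estimated value for compound 4 is 300 nM, with an expected range of 15 nM to 5000 nM. The expected step is a 76-fold lower number from compound 3 to compound 4 (1.88 log units; beyond the scatter).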

Compound 4, half-maximal effective concentration: 1.29 nM
Compound 4: middle estimate off by 230-fold (2.37 log units), on the high side; the whole stated range lies above it.
By their numbers in this assay, from the lowest: compound 4; then compound 2; then compounds 3 and 1 (each within the scatter of the next).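

In this assay, changing the aryl group on the saturated ring carbon moves the number much further than compounds 1 to 3 showed: an 18000-fold lower number from compound 3 to compound 4 (4.25 log units; beyond the scatter) and a 31000-fold lower number from compound 1 to compound 4 (4.49 log units; beyond the scatter) both exceed every earlier step. Going from 3-hydroxyphenyl to 3-bromophenyl gives a 780-fold lower number from compound 2 to compound 4 (2.89 log units; beyond the scatter), so with the substituent's place on the phenyl ring unchanged, the identity of the substituent alone produces a large step. No evidence is available here that accounts for these steps.

Compound 3 and compound 4 differ in both the halogen and its place on the phenyl ring, so these compounds cannot separate the two changes. Going by these compounds, whether a chloro, nitro or methoxy group on the phenyl ring would give a number close to that of compound 4 also stays open.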